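Replacing the amide of compound 3 with a phenylpropylamine

A few compounds are considered here, and "the series" means these few. Any claim that something is new, unique, unknown or untested is made for them only; others in the source may bear on it.

Measured compounds:
compound 1 `O=C(Nc1ccc(S(=O)(=O)N2CCOCC2)c2ccccc12)c1ccccc1` — 7750 nM
compound 2 `CN1CCN(S(=O)(=O)c2ccc(NC(=O)c3ccccc3)c3ccccc23)CC1` — > 30000 nM
compound 3 `CCOC(=O)N1CCC(NS(=O)(=O)c2ccc(C(=O)NC3CCCCC3)c3ccccc23)CC1` — 9.5 nM

In an assay on L1.2 cells for binding affinity to C-C chemokine receptor type 8 (Homo sapiens) (on this read-out higher numbers stand for weaker inhibition and lower numbers for stronger inhibition), compound 3 gives 9.5 nM, the lowest of the two numbers shown. Compound 1 gives 7750 nM in this assay. For compound 2 this assay reports only a limit, > 30000 nM, and no number; one of the three values sits at this limit (the limit of > 30000 nM in this assay, at which 1 of the 3 values shown sits). Among the compounds with values here, the one measured step, an at least 3.8-fold higher number from compound 1 to compound 2 (0.58 log units; beyond the scatter), concerns the amine on the sulfonyl sulfur and does not touch the aromatic carbon that is altered in the next compound. Within the data shown here, compounds 1 and 2 differ from compound 3 in more than one place, so their values give no step to compound 3.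

Compound 4 `CCOC(=O)N1CCC(NS(=O)(=O)c2ccc(NCCCc3ccccc3)c3ccccc23)CC1` differs from compound 3 by (3-phenylpropyl)amino in place of cyclohexylcarbamoyl on an aromatic carbon. Among the measured compounds shown here, no measured step bears on this change; the expectation therefore rests only on the value of compound 3. With no evidence for or against, a modest weakening is expected in this assay, a 3.2-fold higher number from compound 3 to compound 4 (0.50 log units; beyond the scatter), with a wide range. For compound 4 the estimated value in this assay is 30 nM, expected to fall between 5 nM and 200 nM.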

Compound 4, inhibition constant: 32.1 nM
For compound 4 the middle estimate is 1.1-fold (0.03 log units) below the measured one; measured number inside the range.
By their numbers in this assay, from the lowest: compound 3; then compound 4; then compound 1. At a limit, above all of these: compound 2.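

In this assay, within the data shown here, the step of a 3.4-fold higher number from compound 3 to compound 4 (0.53 log units; beyond the scatter) is the first measured change at this aromatic carbon, para to a large group, and it is modest. It shows that cyclohexylcarbamoyl is not required here: with (3-phenylpropyl)amino in its place, a group with the same counts of hydrogen-bond donors and acceptors but an aromatic ring instead of a non-aromatic one and no carbonyl, compound 4 still gives 32.1 nM. Nothing among the data shown accounts for the size of this step.

Among these compounds, the single exchange alters the ring, the chain and the carbonyl together, so the share of each in the step remains open. Also open, going by these compounds, is how a benzylamino group, a longer chain ending in phenyl, or a carboxylic acid at this aromatic carbon would read in this assay, and whether 4-methylpiperazin-1-yl or morpholin-4-yl on the sulfonyl sulfur would have the same effect alongside (3-phenylpropyl)amino.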